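Replacing 4-Methoxyphenyl with Pyridin-2-yl: an Expected Outcome

The source may hold more compounds than are shown below. What is called first, only, known or untested is meant among the compounds shown, and "the series" means these compounds.

Compound 1 `COc1ccc(-c2nc(CNc3ccc(C(=O)NO)cc3)n(-c3ccccc3)n2)cc1` was examined in an assay on Sf9 cells for inhibition of protein deacetylase HDAC6 (Homo sapiens), read by fluorescence, with a stated time of 40 min, tested at 100 nM (a higher number here means more inhibition at the concentration tested (going by the name of the read-out), a lower number less inhibition), where compound 1 gives 77.6%. This is the highest of the two numbers recorded so far. Its nearest neighbour, compound 2 `O=C(NO)c1ccc(NCc2nc(-c3ccccc3)nn2-c2ccc(Cl)cc2)cc1`, gives 55.4% in this assay, and that gap lies beyond the usual scatter of the measurement. For the measured compounds named here, no pair of measured compounds differs in only one place, so these two values are all that can be set side by side.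

Compound 3 `O=C(NO)c1ccc(NCc2nc(-c3ccccn3)nn2-c2ccccc2)cc1` has not yet been measured in this assay. It differs from compound 1 in a single place: pyridin-2-yl in place of 4-methoxyphenyl on an aromatic carbon. The rest of the shared core and the phenyl group are retained.

Going by the values given here, with no measured step of this type to draw on, a modest loss or no change beyond the scatter is the expected result. Compound 3 is estimated to give 68% in this assay, with a likely range from 45% to 85%. The step this estimate implies, a number 9.6 percentage points lower from compound 1 to compound 3 (within the scatter), is expected to fall near the edge of the scatter.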

Compound 3, a percentage reported as inhibition, at one concentration (the size of the read-out at that concentration, not a potency): 58.6%
Estimate against measurement, compound 3: 9.4 percentage points above; measured number inside the range.
By their numbers in this assay, from the lowest: compounds 2 and 3 (each within the scatter of the next); then compound 1.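

For the compounds shown here, the exchange of 4-methoxyphenyl for pyridin-2-yl, on the aromatic carbon between two ring nitrogen atoms, provides the first measured step at this position: in this assay it gives a number 19 percentage points lower from compound 1 to compound 3 (beyond the scatter). The phenyl group and the rest of the shared core are retained, so the result shows that the number responds to the group at this position, and that a six-membered aromatic ring with 1 hetero atom does not match the 4-methoxyphenyl group here, although both groups count the same hydrogen-bond donors and acceptors. Nothing measured here bears on the reason for this step.

The compounds shown leave open whether the step follows from losing the methoxy group or from placing a nitrogen in the ring, a question that an unsubstituted phenyl group at this position would help to separate. Also open, as far as these compounds go, is how pyridin-3-yl or pyridin-4-yl, or a 4-ethoxyphenyl or 4-aminophenyl group, would compare with 4-methoxyphenyl at the same place on the shared core.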